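The source may report more compounds than this note shows. Statements on the series, on what has been measured and on what is new or still open speak of the compounds shown alone.

Measured compounds in a functional assay on MCF cells (Homo sapiens) for antiproliferative activity, with a stated time of 72 h; on this read-out higher numbers stand for weaker inhibition and lower numbers for stronger inhibition:

- compound 1 `OC[C@H]1O[C@@H](n2cnc3c(NCc4cccc(F)c4)ncnc32)[C@H](O)[C@@H]1O` gives 15300 nM
- compound 2 `COc1cccc(CNc2ncnc3c2ncn3[C@@H]2O[C@H](CO)[C@@H](O)[C@H]2O)c1`; for compound 2 this assay reports only a limit, > 166000 nM
- compound 3 `OC[C@H]1O[C@@H](n2cnc3c(NCc4ccc(Cl)cc4Cl)ncnc32)[C@H](O)[C@@H]1O` gives 127000 nM

Among the two numbers shown, compound 3 stands at the highest; its nearest neighbour is compound 1, and the gap between them is an 8.3-fold higher number from compound 1 to compound 3 (0.92 log units; beyond the scatter), a step that exchanges the group on the saturated chain carbon bound to a nitrogen on the aromatic ring. From compound 2 to compound 3 the step is an at least 1.3-fold lower number from compound 2 to compound 3 (0.11 log units; that floor lies within the scatter), which rests on a limit of > 166000 nM in this assay, at which 1 of the 3 values shown sits, and so tells little.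

Compound 4 `OC[C@H]1O[C@@H](n2cnc3c(NCc4ccc(F)c(Cl)c4)ncnc32)[C@H](O)[C@@H]1O` is not yet measured. It differs from compound 3 as follows: 3-chloro-4-fluorophenyl in place of 2,4-dichlorophenyl on a saturated chain carbon bound to a nitrogen on an aromatic ring. For the measured compounds named here, the one measured step that bears on this change is the one from compound 1 to compound 3, where a fluorine-bearing ring was exchanged for the 2,4-dichlorophenyl and the number rose. Compound 4 carries a 3-chloro-4-fluorophenyl, and the step from compound 3 to compound 4 is therefore expected to lower the number in this assay, though with a single relevant comparison the size is uncertain; the estimated step is a 2.5-fold lower number from compound 3 to compound 4 (0.40 log units; beyond the scatter).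

Compound 4 is thus expected to give about 50000 nM in this assay, within a range from 15000 nM to 160000 nM.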

Compound 4, half-maximal inhibitory concentration: > 166000 nM
Compound 4 gave a limit, no number (the forecaster's own chance of this, stated with the estimate: 15%); middle value at least 3.3-fold (0.52 log units) away from the limit.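

In this assay compound 4 reports only a limit, > 166000 nM. Against the 2,4-dichlorophenyl ring, 3-chloro-4-fluorophenyl gives an at least 1.3-fold higher number from compound 3 to compound 4 (0.11 log units; that floor lies within the scatter), so no change can be claimed, while against the 3-fluorophenyl ring it gives an at least 10-fold higher number from compound 1 to compound 4 (1.03 log units; beyond the scatter); a fluorine on the ring is therefore not enough to hold the lower number, and 3-fluorophenyl remains the only group at this place with a number well clear of the others. The step between the 3-methoxyphenyl and 3-chloro-4-fluorophenyl compounds cannot be read, and the ceiling of the assay now limits what can be said about changes at this place: the limit of > 166000 nM in this assay, at which 2 of the 4 values shown sit.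

On these data alone, how far compound 2 and compound 4 lie past their limits remains open, as does whether any feature of the 3-fluorophenyl ring is specifically tied to the lower number of compound 1. Also open, as far as these compounds go, is whether a plain benzyl, a 3-chlorobenzyl or a longer chain carrying the phenyl ring would stay close to compound 1 or join the weak end of the series.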